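The source may report more compounds than this note shows. Statements on the series, on what has been measured and on what is new or still open speak of the compounds shown alone.

Working notes on the amide series, all tested in a functional assay on HCT-116 cells (Homo sapiens) for inhibition, read by MTT assay, with a stated time of 72 h; a lower number here means a stronger inhibitor, a higher number a weaker inhibitor. Compound 1 `Cc1ccc(NC(=O)c2ccc(/N=N\c3c[nH]c4ccccc34)cc2)cc1` gives 25400 nM. Compound 2 `O=C(Nc1ccccc1[N+](=O)[O-])c1ccc(/N=N\c2c[nH]c3ccccc23)cc1` gives 208000 nM. Compound 3 `Cc1ccc(NC(=O)c2ccc(/N=N\c3c[nH]c4ccccc34)cc2)c(C)c1` gives 76100 nM. Compound 2 thus carries the highest of the three numbers, and both gaps to it lie beyond the scatter: a 2.7-fold lower number from compound 2 to compound 3 (0.44 log units; beyond the scatter) is the nearer one, an 8.2-fold higher number from compound 1 to compound 2 (0.91 log units; beyond the scatter) the wider one.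

Compound 4 `O=C(Nc1cccc(Cl)c1)c1ccc(/N=N\c2c[nH]c3ccccc23)cc1` remains to be measured in this assay. The change from compound 2 is 3-chlorophenyl in place of 2-nitrophenyl on an amide-type nitrogen. Among the compounds with values here, two measured steps bear on it, as both also swap the aryl group on the amide-type nitrogen: an 8.2-fold higher number from compound 1 to compound 2 (0.91 log units; beyond the scatter) and a 2.7-fold lower number from compound 2 to compound 3 (0.44 log units; beyond the scatter). In both cases the 2-nitrophenyl compound sits at the high end, so moving away from 2-nitrophenyl to any other aryl tested so far has meant a lower number. Within the data shown here, no measured compound carries a chlorine on that ring, so the exact size is open; the expectation is a drop of about the size seen for the methyl-bearing aryls, which is a 4.6-fold lower number from compound 2 to compound 4 (0.66 log units; beyond the scatter). On that basis compound 4 is estimated at 45000 nM, with a likely range from 12000 nM to 160000 nM.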

Compound 4, half-maximal inhibitory concentration: 80000 nM
For compound 4 the middle estimate is 1.8-fold (0.25 log units) below the measured one; measured number inside the range.
By their numbers in this assay, from the lowest: compound 1; then compounds 3 and 4 (each within the scatter of the next); then compound 2.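

On the amide-type nitrogen, 3-chlorophenyl in place of 2-nitrophenyl gives a 2.6-fold lower number from compound 2 to compound 4 (0.41 log units; beyond the scatter) in this assay, so a chlorine-bearing aryl group now joins the two methyl-bearing ones in lying below the 2-nitrophenyl compound, with every step from it beyond the scatter. The new aryl group does not reach the 4-methylphenyl compound, as a 3.1-fold higher number from compound 1 to compound 4 (0.50 log units; beyond the scatter) shows, and that compound keeps the lowest number, with its steps to all three others beyond the scatter. The comparison with the 2,4-dimethylphenyl compound gives a 1.1-fold higher number from compound 3 to compound 4 (0.02 log units; within the scatter), so 3-chlorophenyl and 2,4-dimethylphenyl cannot be told apart here, even though one carries a chlorine and the other two methyl groups.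

Nothing available explains why these aryl groups separate as they do. Still open, as far as these compounds go, is where an unsubstituted phenyl, a phenyl bearing an amine or a carboxylic acid, or a longer alkyl chain in place of the aryl group on the amide-type nitrogen would fall relative to the 4-methylphenyl compound, and whether any such group would go below it.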